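This account rests on a few compounds, and the source may have more. Where it says the series, first, only, none or still open, it means among the compounds named here.

Compound 3, `N#Cc1c(N2CCC(c3ccccc3)CC2)ccn(CC2CC2)c1=O`, stands second highest of the three compounds measured in a functional assay on CHO cells for positive allosteric modulation of metabotropic glutamate receptor 2 (Homo sapiens), with a stated time of 30 min (a higher number here means a larger maximal response, a lower number a smaller maximal response), where compound 3 gives 309%. Its nearest neighbour is compound 1, `CC(C)Cn1ccc(N2CCC(c3ccccc3)CC2)c(C#N)c1=O`, which in this assay gives 316%, so that the step of a number 7 percentage points lower from compound 1 to compound 3 (within the scatter). Compound 2, `N#Cc1c(N2CCC(c3ccccc3)CC2)ccn(CC2CCC2)c1=O`, gives 269%, and the step of a number 40 percentage points higher from compound 2 to compound 3 (beyond the scatter); likewise the step of a number 47 percentage points lower from compound 1 to compound 2 (beyond the scatter). Compound 4, `N#Cc1c(N2CCC(c3ccccc3F)CC2)ccn(CC2CC2)c1=O`, differs from compound 3 in one place: fluoro in place of hydrogen on an aromatic carbon. Within the data shown here, none of the measured steps concerns this part of the molecule; all three change the group on the saturated chain carbon bound to the aromatic nitrogen, and they say nothing about the phenyl ring. There is therefore no direct guide, and the step of a number 9 percentage points lower from compound 3 to compound 4 (within the scatter) is expected to stay within the usual scatter. For compound 4 the estimate in this assay is 300%, with a range from 250% to 350%.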

Compound 4, largest response reached (Emax), in percent of the reference or control that the assay uses: 282%
Estimate against measurement, compound 4: 18 percentage points above, and the stated range covers the measured number.
By their numbers in this assay, from the lowest: compound 2; then compound 4; then compounds 3 and 1 (each within the scatter of the next).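

Among these compounds, the phenyl ring, which no earlier step touched, proves responsive in this assay: going from phenyl to 2-fluorophenyl gives a modest fall in maximal response (a number 27 percentage points lower from compound 3 to compound 4 (beyond the scatter)). A single fluoro on an aromatic carbon, ortho to a large group, is thus enough to move this read-out beyond the scatter, so changes at the ring count as well as changes at the group on the saturated chain carbon. Nothing among the data shown accounts for the fall.

On these data alone, whether chloro, methoxy or hydroxyl in the same place would lower the response as well remains open. So does whether fluoro would have the same effect with the isopropyl of compound 1 or the cyclobutyl of compound 2 in place of the cyclopropyl.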